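The source may hold more compounds than are shown below. What is called first, only, known or untested is meant among the compounds shown, and "the series" means these compounds.

Measured so far in an ADME assay on CEM-SS cells (Homo sapiens) for cytotoxicity, read by XTT assay, with a stated time of 6 days; on this read-out lower numbers stand for higher toxicity in this test and higher numbers for lower toxicity in this test:
Compound 1 `CCCC(=O)OCSc1ccccc1C(=O)NCCC(N)=O`: > 100 uM
Compound 2 `CCCC(=O)OCSc1ccccc1C(=O)NCC(N)=O`: > 100 uM

Compound 2 stands only at a limit, > 100 uM, and not at a number. Within the data shown here, the series so far rests on (the limit of > 100 uM in this assay, at which 2 of the 2 values shown sit).

Compound 3 `CCCC(=O)OCSc1ccccc1C(=O)NC1(C(N)=O)CCCC1` has not yet been measured in this assay. The change is 1-carbamoylcyclopentyl in place of carbamoylmethyl on an amide-type nitrogen.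

Among the measured compounds shown here, the only measured step that bears on this change is a step that the two limits leave unreadable from compound 1 to compound 2. For the measured compounds named here, it gives neither a size nor a direction, and it concerns a smaller change than the one at hand, so the series offers no measured precedent for the entering group.

No step beyond the scatter is therefore expected in this assay, though this expectation is weakly supported. It rests on compound 2 and its limit of > 100 uM. The expected step is a number no higher from compound 2 to compound 3 (the limit leaves the size open). Another limit rather than a number is the most likely report. For compound 3 the estimated value is 100 uM, with an expected range from 40 uM to 200 uM.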

Compound 3, half-maximal toxic concentration: > 100 uM
Compound 3 gave a limit, no number (the forecaster's own chance of this, stated with the estimate: 75%); the middle value sits exactly at the limit.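

In this assay compound 3 gives > 100 uM, which is a limit. No step can be read among compound 1, compound 2 and compound 3, as the series sits at one limit: the limit of > 100 uM in this assay, at which 3 of the 3 values shown sit.

The compounds shown leave open at what concentration any of them reaches half-maximal toxicity in this assay, and whether 1-carbamoylcyclopentyl in place of carbamoylmethyl changes that concentration.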